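From ethyl to carboxy on the ring of compound 2

The source may hold more compounds than are shown below. What is called first, only, known or untested is meant among the compounds shown, and "the series" means these compounds.

Compound 2 `CCc1ccc2[nH]c(CC(CC(=O)O)c3ccc(Cl)cc3)nc2c1` gives 0% in an assay on isolated protein for inhibition of protein kinase C zeta type (Homo sapiens), read by 33P incorporation, tested at 50 uM (a lower number here means a weaker effect, a higher number a stronger effect of the compound at the concentration tested), the lowest of the two numbers seen so far; its nearest neighbour, compound 1 `O=C(O)CC(Cc1nc2cc(C(F)(F)F)ccc2[nH]1)c1ccc(Cl)cc1`, gives 35% in this assay. Among the measured compounds shown here, the only measured step at this position, a number 35 percentage points lower from compound 1 to compound 2 (beyond the scatter), shows that changing the group there can move the read-out a long way. Compound 3 `O=C(O)CC(Cc1nc2cc(C(=O)O)ccc2[nH]1)c1ccc(Cl)cc1` differs from compound 2 by carboxy in place of ethyl on an aromatic carbon. For the measured compounds named here, no measured step covers a carboxy here, so the direction is open. Compound 3 is expected to show 10% (range 0% to 35%), a step of a number 10 percentage points higher from compound 2 to compound 3 (within the scatter).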

Compound 3, a percentage reported as inhibition, at one concentration (the size of the read-out at that concentration, not a potency): 0%
Estimate against measurement, compound 3: 10 percentage points above; the measured number falls inside the stated range.
By their numbers in this assay, from the lowest: compounds 2 and 3 (each within the scatter of the next); then compound 1.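

Carboxy and ethyl on this aromatic carbon cannot be told apart in this assay, with no change at the digits printed from compound 2 to compound 3 (within the scatter) at this position. Trifluoromethyl now stands apart from two different groups rather than one, with a number 35 percentage points lower from compound 1 to compound 3 (beyond the scatter) in the second comparison, so among these three compounds only compound 1 gives a read-out above zero. Nothing available here explains this difference.
Going by these compounds, whether a chlorine, a nitrile or a methoxy group on this carbon would give a read-out like that of compound 1 remains open. So does the effect of an amine there.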